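A few compounds are considered here, and "the series" means these few. Any claim that something is new, unique, unknown or untested is made for them only; others in the source may bear on it.

Compound 1 `COC(=O)[C@@]1(C)CCC=C2[C@@H]1CC[C@@H](C)[C@]2(C)Cc1c[nH]c2ccc(OC)cc12` and compound 2 `COC(=O)[C@@]1(C)CCC=C2[C@@H]1CC[C@@H](C)[C@]2(C)Cc1c(C)[nH]c2ccc(OC)cc12` share one core, while compound 3 `COC(=O)[C@@]1(C)CC[C@@H]2C3=C1CC[C@@H](C)[C@]3(C)Cc1c2[nH]c2ccccc12` and compound 4 `COC(=O)[C@@]1(C)CC[C@@H]2C3=C1CC[C@@H](C)[C@]3(C)Cc1c2[nH]c2ccc(C)cc12` share another; the difference between the two cores is not broken down here. In a functional assay on HeLa cells (Homo sapiens) for inhibition, read by sulforhodamine B assay, with a stated time of 48 h (a lower number here means a stronger inhibitor of growth, a higher number a weaker inhibitor of growth), compound 1 gives 1200 nM, compound 2 gives 12000 nM and compound 3 gives 3200 nM. The change methyl in place of hydrogen on an aromatic carbon produced a 10-fold higher number from compound 1 to compound 2 (1.00 log units; beyond the scatter). The change methyl in place of hydrogen on an aromatic carbon is the same kind of change, yet it sits in a different place: on an aromatic carbon of a six-membered aromatic ring of carbon only, meta to a fused ring and para to a fused ring, rather than on a five-membered aromatic ring with 1 nitrogen, next to the ring nitrogen. The step in this assay is therefore expected to be smaller, a 1.4-fold higher number from compound 3 to compound 4 (0.15 log units; within the scatter), because the earlier step of a 10-fold higher number from compound 1 to compound 2 (1.00 log units; beyond the scatter) came from a different place. Compound 4 is estimated at 4500 nM.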

Compound 4, concentration for 50% growth inhibition: 11000 nM
Compound 4: middle estimate off by 2.4-fold (0.39 log units), on the low side; the range from low to high includes it.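

In this assay, methyl in place of hydrogen on an aromatic carbon gives a 3.4-fold higher number from compound 3 to compound 4 (0.54 log units; beyond the scatter) and so moves the number in the same direction as on the first core, towards weaker growth inhibition. The direction carries across these two pairs, but the size does not: the same change on two cores in this assay, a 10-fold higher number (1.00 log units; beyond the scatter) from compound 1 to compound 2 and a 3.4-fold higher number (0.54 log units; beyond the scatter) from compound 3 to compound 4, 2.9-fold (0.46 log units) apart, beyond the scatter of two such steps. The methyl also sits in a different place on each core, so these two pairs cannot separate the effect of the core from the effect of the position, and they establish no general rule.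

Going by these compounds, it remains open whether a longer chain, an amine or a carboxylic acid on that aromatic carbon would also give a higher number. On these data alone, the size of the step for a methyl at one same place on both cores is also open.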